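This account rests on a few compounds, and the source may have more. Where it says the series, first, only, none or still open, it means among the compounds named here.

The series shares one core, carried by compound 1 `CCCCCCNc1nc(-c2ccccc2)nc2c1nnn2Cc1ccccc1`, compound 2 `CCNc1nc(-c2ccccc2)nc2c1nnn2Cc1ccccc1Cl` and compound 3 `OCCCNc1nc(-c2ccccc2)nc2c1nnn2Cc1ccccc1Cl`. In an assay on isolated protein for binding affinity to adenosine receptor A1 (Bos taurus) (on this read-out higher numbers stand for weaker inhibition and lower numbers for stronger inhibition), compound 1 gives 13200000 nM. In the same assay compound 2 gives 463000000 nM. Compound 3 gives 33000000 nM, which places it second highest of the three numbers, nearest to compound 1 and furthest from compound 2. Among the compounds with values here, the only step so far between compounds that differ in a single place is a 14-fold lower number from compound 2 to compound 3 (1.15 log units; beyond the scatter). Compound 4 `OCCCNc1nc(-c2ccccc2)nc2c1nnn2Cc1ccccc1` differs from compound 3 by hydrogen in place of chloro on an aromatic carbon. Within the data shown here, no measured pair isolates this change: compound 1 and compound 3 differ in two places at once, so the gap between them cannot be read as a step for the chloro alone, and the step from compound 2 to compound 3 concerns the hydroxymethyl and says nothing about the chloro. No step beyond the scatter is therefore expected; the expected step is a 1.3-fold lower number from compound 3 to compound 4 (0.12 log units; within the scatter). For compound 4 the estimate in this assay is 25000000 nM, within a range from 8000000 nM to 80000000 nM.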

Compound 4, inhibition constant: 21400000 nM
Estimate against measurement, compound 4: 1.2-fold (0.07 log units) above, within the range that was stated.
By their numbers in this assay, from the lowest: compounds 1, 4 and 3 (each within the scatter of the next, the first and the last beyond it); then compound 2.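

In this assay, within the data shown here, the pair compound 3 and compound 4 isolates the chloro for the first time, and a 1.5-fold lower number from compound 3 to compound 4 (0.19 log units; within the scatter) shows that hydrogen in its place on this aromatic carbon leaves the number unresolved from that of the 2-chlorobenzyl compound, at least with this hydroxy-ended chain. The other new pair, a 1.6-fold higher number from compound 1 to compound 4 (0.21 log units; within the scatter) in this assay, shows that with the benzyl group in place, hydroxy in place of propyl at the chain end likewise stays unresolved. No measurement is at hand that would explain either result.

Going by these compounds, whether the chloro matters as little with the short ethyl chain of compound 2 remains open, since that chain appears here only with the 2-chlorobenzyl group. Also open, on these data alone, is how a methoxy group at this aromatic carbon, or an amine or a carboxylic acid at the chain end, would read.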